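The compounds below may be only part of what the source reports. "The series", "measured", "known", "first", "only" and "open" are said of these compounds alone.

Measured so far in a functional assay on SMMC-7721 cells (Homo sapiens) for antiproliferative activity, read by MTT assay, with a stated time of 48 h; on this read-out higher numbers stand for weaker inhibition and lower numbers for stronger inhibition:
- Compound 1 `Cn1cc(C2=C(c3nn(CCCn4cccc4)c4ncccc34)C(=O)NC2=O)c2ccccc21`: > 100000 nM
- Compound 2 `Cn1cc(C2=C(c3nn(CCCN4CCCCC4)c4ncccc34)C(=O)N(c3ccccn3)C2=O)c2ccccc21`: > 100000 nM

Compound 1 offers no exact number, because its > 100000 nM is a limit of the assay. Compound 2 likewise gives only a limit, > 100000 nM. For these two compounds, the data show (the limit of > 100000 nM in this assay, at which 2 of the 2 values shown sit). Among the measured compounds shown here, they cannot be ranked against each other, and no measured step is available as a guide.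

The next compound, compound 3 `Cn1cc(C2=C(c3n[nH]c4ncccc34)C(=O)NC2=O)c2ccccc21`, keeps the core of compound 1 but loses its side chain: hydrogen in place of 3-(1H-pyrrol-1-yl)propyl on an aromatic nitrogen. In words, this is hydrogen in place of 3-(1H-pyrrol-1-yl)propyl on an aromatic nitrogen.

With compound 1 reported as > 100000 nM, a limit, a measurable result for compound 3 could only point toward stronger inhibition. The expected change is modest, and the assay may well return only a limit again. In numbers, the expected change is an at least 2.5-fold lower number from compound 1 to compound 3 (0.39 log units; beyond the scatter). Compound 3 is estimated at 40000 nM, with an expected range of 8000 nM to 100000 nM.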

Compound 3, half-maximal inhibitory concentration: > 100000 nM
Compound 3: a limit, no number; the forecaster's own chance of this, stated with the estimate: 40%; middle value at least 2.5-fold (0.39 log units) away from the limit.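

In this assay compound 3 gives > 100000 nM, which is a limit and not a number. Among the compounds shown here, compound 1 also stands at a limit, so no step between compound 1 and compound 3 can be read. The compounds shown leave open how strongly each inhibits these cells, and whether hydrogen in place of 3-(1H-pyrrol-1-yl)propyl changes anything: the limit of > 100000 nM in this assay, at which 3 of the 3 values shown sit.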